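The source may report more compounds than this note shows. Statements on the series, on what has been measured and on what is new or still open speak of the compounds shown alone.

In a functional assay on the whole organism (blood) with Rattus norvegicus as the target, with stated times of 24 h and 1 h, at a dose of 15 mg/kg by the intraperitoneal route (a lower number here means a weaker effect, a higher number a stronger effect of the compound at the dose given), compound 1 `O=C(NC[C@@H]1C[C@@H]2C=C[C@@H]1C2)NS(=O)(=O)N1CCC(CCNC(=O)c2cscn2)CC1` gives 37% and compound 3 `COc1ccc(C(=O)NCCC2CCN(S(=O)(=O)NC(=O)NC[C@@H]3C[C@@H]4C=C[C@@H]3C4)CC2)cn1` gives 32%. Compound 2 `CSc1ccc(C(F)(F)F)cc1C(=O)NCCC1CCN(S(=O)(=O)NC(=O)NC2CCCCC2)CC1` gives 24%; this number sits within the usual scatter of compound 3 and lies beyond the scatter only against compound 1. Compound 4 `O=C(NC1CCCCC1)NS(=O)(=O)N1CCC(CCNC(=O)c2cccc3c2OCCO3)CC1` has not yet been measured in this assay. It differs from compound 2 in one place: a group of 10 heavy atoms (8 carbon, 2 oxygen; one six-membered non-aromatic ring with 2 hetero atoms, one six-membered aromatic ring of carbon only) in place of a group of 12 heavy atoms (8 carbon, 3 fluorine, 1 sulfur; one six-membered aromatic ring of carbon only), on a carbonyl carbon. Going by the values given here, the one measured step that also swaps the group on a carbonyl carbon is a number 5 percentage points lower from compound 1 to compound 3 (within the scatter), though there 6-methoxypyridin-3-yl replaced 1,3-thiazol-4-yl on a different core. Because a number 5 percentage points lower from compound 1 to compound 3 (within the scatter) stayed within the scatter, the expected step is a number 4 percentage points higher from compound 2 to compound 4 (within the scatter), nothing beyond the scatter. Compound 4 is therefore estimated at 28%, within a range from 10% to 48%.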

Compound 4, a percentage reported as activity, at one dose (the size of the read-out at that dose, not a potency): 42%
Beside the measured number, compound 4's estimate is 14 percentage points below it; measured number inside the range.
By their numbers in this assay, from the lowest: compounds 2, 3, 1 and 4 (each within the scatter of the next, the first and the last beyond it).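

In this assay, putting 2,3-dihydro-1,4-benzodioxin-5-yl on the carbonyl carbon gives a number 18 percentage points higher from compound 2 to compound 4 (beyond the scatter) with the rest of the molecule unchanged. Going by these compounds alone, this shows that the group at this place can shift the read-out beyond the scatter, which the one earlier step here did not show. No evidence on the cause of this rise is available.

Going by these compounds, it remains open whether the whole 2,3-dihydro-1,4-benzodioxin-5-yl group is needed, or whether a plain phenyl group would serve equally. On these data alone, whether this group has the same effect on the core of compound 1 also remains open.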